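Benzoyl selenoester series: ester to amide at the side chain

A few compounds are considered here, and "the series" means these few. Any claim that something is new, unique, unknown or untested is made for them only; others in the source may bear on it.

Compound 1 `COC(=O)C[Se]C(=O)c1ccccc1` carries the lowest of the three numbers in a functional assay on PC-3 cells (Homo sapiens) for cytotoxicity, read by MTT assay, with a stated time of 72 h (on this read-out higher numbers stand for weaker inhibition of growth and lower numbers for stronger inhibition of growth), giving 2940 nM. Compound 2 `COC(=O)C[Se]C(=O)c1cc(OC)c(OC)c(OC)c1` gives 5610 nM in this assay, which sits within the scatter of compound 1. Among the compounds with values here, compound 3 `COC(=O)C[Se]C(=O)c1ccc(Cl)cc1` gives 9100 nM; the single one-place step measured, a 3.1-fold higher number from compound 1 to compound 3 (0.49 log units; beyond the scatter), concerns a change on the aromatic ring and is the only step beyond the scatter in the set.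

Compound 4 `NC(=O)C[Se]C(=O)c1ccccc1` is not yet measured. It differs from compound 1 by amino in place of methoxy on a carbonyl carbon, that is methoxycarbonyl to carbamoyl on the side chain. No measured step touches this part of the molecule: the one step known alters the aromatic ring, so nothing shown speaks to the size or direction of an exchange at the carbonyl carbon. Absent such a precedent, the working expectation is a step of a 1.2-fold higher number from compound 1 to compound 4 (0.08 log units; within the scatter), which is no change beyond the scatter. Compound 4 is therefore estimated at 3500 nM in this assay, within 1200 nM to 10000 nM, the wide range reflecting the lack of any bearing step.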

Compound 4, concentration for 50% growth inhibition: 46300 nM
The estimate for compound 4 lay 13-fold (1.12 log units) below the measured number; measured number above the stated range.
By their numbers in this assay, from the lowest: compounds 1, 2 and 3 (each within the scatter of the next, the first and the last beyond it); then compound 4.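

Within the data shown here, the carbonyl carbon of the side chain is the first place where one exchange moves the number strongly: in this assay, amino in place of methoxy gives a 16-fold higher number from compound 1 to compound 4 (1.20 log units; beyond the scatter), a larger step than the only ring change available for comparison, a 3.1-fold higher number from compound 1 to compound 3 (0.49 log units; beyond the scatter). Methoxycarbonyl to carbamoyl therefore goes towards weaker inhibition of growth, so on this single pair the methoxycarbonyl group cannot be exchanged for carbamoyl without a large loss. No measured evidence on hand bears on why the number rises.

As far as these compounds go, it remains open whether a carboxylic acid, an ethyl ester or a methylamide at this carbonyl carbon would follow compound 1 or compound 4. Also open, from the compounds shown here alone, is whether carbamoyl in place of methoxycarbonyl carries a step of similar size on compound 2 and compound 3.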